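The source may report more compounds than this note shows. Statements on the series, on what has been measured and on what is new or still open speak of the compounds shown alone.

In a functional assay on KM12 cells (Homo sapiens) for inhibition, read by sulforhodamine B assay, with a stated time of 96 h (a higher number here means a weaker inhibitor of growth, a lower number a stronger inhibitor of growth), compound 3 `CC[C@H](Nc1nc(NCc2ccccn2)c2ncn(C(C)C)c2n1)C(C)(C)O` gives 38000 nM. Compound 1 `CCC(O)[C@@H](CC)Nc1nc(NCc2ccccn2)c2ncn(C(C)C)c2n1` gives 45000 nM and compound 2 `CC[C@@H](Nc1nc(NCc2ccccn2)c2ncn(C(C)C)c2n1)C(O)C(C)(C)C` gives 45000 nM, so all three sit level within the scatter. Compound 4 `CCC(O)[C@H](CC)Nc1nc(NCc2ccccn2)c2ncn(C(C)C)c2n1` carries 1-hydroxypropyl in place of 1-hydroxy-1-methylethyl on a saturated chain carbon bound to a nitrogen on an aromatic ring and a saturated chain carbon. Three measured steps alter this same substituent: a 1.2-fold lower number from compound 1 to compound 3 (0.07 log units; within the scatter), a 1.2-fold lower number from compound 2 to compound 3 (0.07 log units; within the scatter) and no change at the digits printed from compound 1 to compound 2 (within the scatter). None exceeds the scatter, so no step beyond the scatter is expected in this assay. The expected step is a 1.1-fold higher number from compound 3 to compound 4 (0.02 log units; within the scatter). For compound 4 the estimated value is 40000 nM, within an expected range of 20000 nM to 80000 nM.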

Compound 4, concentration for 50% growth inhibition: > 50000 nM
Compound 4: only a limit was reported; the forecaster's own chance of this, stated with the estimate: 10%; at least 1.2-fold (0.09 log units) between middle value and limit.
By their numbers in this assay, from the lowest: compounds 3, 1 and 2 (each within the scatter of the next). At a limit, above all of these: compound 4.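

In this assay compound 4 gives only a limit, > 50000 nM. Its steps are floors that stay within the scatter, an at least 1.3-fold higher number from compound 3 to compound 4 (0.11 log units; that floor lies within the scatter), an at least 1.1-fold higher number from compound 2 to compound 4 (0.04 log units; that floor lies within the scatter) and an at least 1.1-fold higher number from compound 1 to compound 4 (0.04 log units; that floor lies within the scatter), so 1-hydroxypropyl in place of 1-hydroxy-1-methylethyl at this position is not shown to separate from the earlier compounds. The pairing of compound 1 with compound 4 is no clean test of configuration at this carbon: the fact that one of compounds 1 and 4 is drawn with a defined configuration and the other without, at the place where they differ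

As far as these compounds go, the true size of each step to compound 4 stays open. Also open, from the compounds shown here alone, is whether an amine or a carboxylic acid in place of the hydroxy group would move the number beyond the scatter.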